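Thiazole acetic acids: removing the nitrile of compound 1

A few compounds are considered here, and "the series" means these few. Any claim that something is new, unique, unknown or untested is made for them only; others in the source may bear on it.

Compound 1 `N#Cc1ccc(-c2nc(C(c3ccc(F)cc3)c3ccc(F)cc3)sc2CC(=O)O)cc1` carries a 4-cyanophenyl on the shared core. In an in vitro functional assay on HEK285-7 cells for antagonist activity at prostaglandin D2 receptor 2 (Homo sapiens), read by BRET and beta-arrestin recruitment (a lower number here means a smaller maximal response, a higher number a larger maximal response), compound 1 gives 30%. Compound 3 `O=C(O)Cc1sc(NCc2ccccc2)nc1-c1ccc(Cl)cc1` gives 30%, a value level with compound 1 at the digits shown, and the two sit together as the lowest of the three numbers. Compound 2 `O=C(O)Cc1sc(NC(=O)c2ccccc2)nc1-c1ccc(Cl)cc1` gives 50%, the highest of the set.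

For the measured compounds named here, the one measured step, a number 20 percentage points lower from compound 2 to compound 3 (beyond the scatter), concerns benzyl in place of benzoyl on a nitrogen on the core, a part of the molecule that compound 1 and compound 4 do not share. It therefore says nothing direct about the change at hand.

Compound 4 `O=C(O)Cc1sc(C(c2ccc(F)cc2)c2ccc(F)cc2)nc1-c1ccccc1` differs from compound 1 by hydrogen in place of cyano on an aromatic carbon, on an aromatic carbon of a six-membered aromatic ring of carbon only, para to a large group; cut one bond further out, 4-cyanophenyl becomes phenyl. Going by the values given here, no measured step touches this ring, so no shift beyond the scatter is expected, and the step of no change at the digits printed from compound 1 to compound 4 (within the scatter) is estimated as essentially flat. For compound 4 the expected efficacy is 30%, with a range of 15% to 50%.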

Compound 4, largest response reached (reported as efficacy), in percent of the reference or control that the assay uses: 80%
Beside the measured number, compound 4's estimate is 50 percentage points below it; measured number outside the range, above it.
By their numbers in this assay, from the lowest: compounds 1 and 3 (each within the scatter of the next); then compound 2; then compound 4.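

The para position on this six-membered aromatic ring is not a neutral place on the core of compound 1: in this assay hydrogen in place of cyano gives a number 50 percentage points higher from compound 1 to compound 4 (beyond the scatter), although only a cyano group of 2 heavy atoms leaves. For the compounds shown here, the earlier compounds showed a change only at the nitrogen, so this is the first measured step at this ring. Nothing at hand accounts for the size or the direction of this step.

On these data alone, whether a methoxy group, an amine or a carboxylic acid on this carbon would read closer to compound 1 or to compound 4 remains open. So does whether hydrogen in place of chlorine on the ring of compound 2 or compound 3 would shift the number in the same way.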